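A few compounds are considered here, and "the series" means these few. Any claim that something is new, unique, unknown or untested is made for them only; others in the source may bear on it.

Measured in a functional assay on HUVEC cells (Homo sapiens) for inhibition; a lower number here means a stronger inhibitor, a higher number a weaker inhibitor:
compound 1 `CN(c1ccc(NC(=O)Nc2ccccc2)cc1)c1ccnc(Nc2cccc(CS(C)(=O)=O)c2)n1`: 0.2 nM
compound 2 `CN(c1ccc(NC(=N)Nc2ccccc2)cc1)c1ccnc(Nc2cccc(CS(C)(=O)=O)c2)n1`: 596 nM
compound 3 `CN(c1ccc(NC(=O)Nc2cc(C(F)(F)F)ccc2F)cc1)c1ccnc(Nc2cccc(S(N)(=O)=O)c2)n1`: 10 nM

Compound 1 holds the lowest of the three numbers. Compound 4 `CN(c1ccc(NC(=O)Nc2c(Cl)cccc2Cl)cc1)c1ccnc(Nc2cccc(CS(C)(=O)=O)c2)n1` departs from it at one place, on an amide-type nitrogen: 2,6-dichlorophenyl in place of phenyl on an amide-type nitrogen. Within the data shown here, the only measured step, a 3000-fold higher number from compound 1 to compound 2 (3.47 log units; beyond the scatter), is large but concerns the carbonyl, not the phenyl, so it gives no direct size for this change. Among the measured compounds shown here, no measured pair isolates substitution on this phenyl. Compound 3 reads 10 nM, a higher number than compound 1 shows. With compound 1 at the bottom of the measured range, a moderate move toward weaker inhibition is expected, estimated as a 15-fold higher number from compound 1 to compound 4 (1.18 log units; beyond the scatter). The estimate for compound 4 is 3 nM, with an expected range of 0.3 nM to 30 nM.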

Compound 4, half-maximal inhibitory concentration: 29 nM
Beside the measured number, compound 4's estimate is 9.7-fold (0.99 log units) below it; the measured number falls inside the stated range.
By their numbers in this assay, from the lowest: compound 1; then compound 3; then compound 4; then compound 2.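

In this assay the change to 2,6-dichlorophenyl on the amide-type nitrogen gives a 150-fold higher number from compound 1 to compound 4 (2.16 log units; beyond the scatter) as the first direct size for a change on this phenyl, and the position tolerates this group poorly. The loss is smaller than that from replacing the carbonyl oxygen, a 3000-fold higher number from compound 1 to compound 2 (3.47 log units; beyond the scatter) and a 21-fold lower number from compound 2 to compound 4 (1.31 log units; beyond the scatter) place compound 4 well on the stronger side of compound 2. No evidence bears on the origin of this rise.

From the compounds shown here alone, whether a single chlorine, a methyl or a methoxy on this phenyl stays closer to compound 1 remains open.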